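Chloro for methoxy on the pendant ring of compound 3

A few compounds are considered here, and "the series" means these few. Any claim that something is new, unique, unknown or untested is made for them only; others in the source may bear on it.

Measured compounds:
compound 1 `CC(C)c1cc(C(C)(C)C)cc(-c2cccc(C#N)c2)c1CO` > 50000 nM
compound 2 `CC(C)c1cc(C(C)(C)C)cc(-c2cccc(N(C)C)c2)c1CO` 310 nM
compound 3 `COc1cccc(-c2cc(C(C)(C)C)cc(C(C)C)c2CO)c1` 200 nM

In a functional assay on RKE cells for antagonist activity at Vasoactive intestinal polypeptide receptor 1 (Rattus norvegicus), read by HTRF and cAMP accumulation, with stated times of 10 min and 30 min (a lower number here means a stronger inhibitor, a higher number a weaker inhibitor), compound 1 gives only a limit of the assay, > 50000 nM (the limit of > 50000 nM in this assay, at which 1 of the 3 values shown sits). Compound 3 and compound 2 lie within the scatter of each other in this assay: a 1.6-fold lower number from compound 2 to compound 3 (0.19 log units; within the scatter). Replacing cyano gave an at least 160-fold lower number from compound 1 to compound 2 (2.20 log units; beyond the scatter) and an at least 250-fold lower number from compound 1 to compound 3 (2.39 log units; beyond the scatter).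

Compound 4 `CC(C)c1cc(C(C)(C)C)cc(-c2cccc(Cl)c2)c1CO` differs from compound 3 by chloro in place of methoxy on an aromatic carbon. Going by the values given here, no measured step exchanges methoxy for a halogen. The steps from compound 1 show that a cyano group removes activity in this assay, while methoxy and dimethylamino behave alike. Chloro is neither, so the expected change is a 4.0-fold higher number from compound 3 to compound 4 (0.60 log units; beyond the scatter) for compound 4, with wide uncertainty. Compound 4 is therefore estimated at 800 nM in this assay, in the range 150 nM to 8000 nM.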

Compound 4, half-maximal inhibitory concentration: 100 nM
Beside the measured number, compound 4's estimate is 8.0-fold (0.90 log units) above it; measured number outside the range, below it.
By their numbers in this assay, from the lowest: compounds 4, 3 and 2 (each within the scatter of the next, the first and the last beyond it). At a limit, above all of these: compound 1.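

In this assay, chloro, which carries no hydrogen-bond acceptor, replaces methoxy with a 2.0-fold lower number from compound 3 to compound 4 (0.30 log units; within the scatter), so activity at this aromatic position does not depend on an acceptor there. Against dimethylamino, chloro gives a 3.1-fold lower number from compound 2 to compound 4 (0.49 log units; beyond the scatter), a modest step beyond the scatter, while replacing cyano gives an at least 500-fold lower number from compound 1 to compound 4 (2.69 log units; beyond the scatter). That last step rests on a limit of the assay: the limit of > 50000 nM in this assay, at which 1 of the 4 values shown sits.

From the compounds shown here alone, whether fluoro, bromo or methyl would match chloro here remains open. So does whether a carboxylic acid would fail as cyano does.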